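Nitro substitution on a benzyloxy aniline across two macrocyclic cores

This account rests on a few compounds, and the source may have more. Where it says the series, first, only, none or still open, it means among the compounds named here.

The study concerns four anilinoquinazoline-type compounds that share a benzyloxy-substituted aniline and differ in the size of a macrocyclic ether bridge and in whether the benzyl ring carries a nitro group. Compound 2 `c1ccc(COc2cccc(Nc3ncnc4cc5c(cc34)OCCOCCO5)c2)cc1` and compound 1 `O=[N+]([O-])c1ccc(COc2cccc(Nc3ncnc4cc5c(cc34)OCCOCCO5)c2)cc1` share the shorter bridge; the change from compound 2 to compound 1 is nitro in place of hydrogen on an aromatic carbon. Compound 3 `c1ccc(COc2cccc(Nc3ncnc4cc5c(cc34)OCCOCCOCCO5)c2)cc1` carries the longer bridge, and the difference between the core of compound 2 and the core of compound 3 is not broken down here.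

In a functional assay on DU-145 cells (Homo sapiens) for antiproliferative activity, read by MTT assay, with a stated time of 72 h (on this read-out higher numbers stand for weaker inhibition and lower numbers for stronger inhibition), compound 2 gives only a limit, > 100000 nM. Compound 1 likewise gives only a limit in this assay, > 100000 nM. Compound 3 also reaches only a limit in this assay, > 100000 nM. The step that the two limits leave unreadable from compound 2 to compound 1 therefore cannot be read in size, and the picture is summed up by the limit of > 100000 nM in this assay, at which 3 of the 3 values shown sit.

Compound 4 `O=[N+]([O-])c1ccc(COc2cccc(Nc3ncnc4cc5c(cc34)OCCOCCOCCO5)c2)cc1` is not yet measured; the change from compound 3 to compound 4 is nitro in place of hydrogen on an aromatic carbon, the same change as from compound 2 to compound 1. Since the nitro group left compound 1 at the limit just as compound 2, and compound 3 already sits at that limit, the step from compound 3 to compound 4 is expected to be a step that the limit leaves unreadable from compound 3 to compound 4 and to remain unreadable in practice. Compound 4 is estimated at 150000 nM in this assay, most probably reported again as a limit rather than a number.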

Compound 4, half-maximal inhibitory concentration: > 100000 nM
Compound 4 gave a limit, no number; the forecaster's own chance of this, stated with the estimate: 85%; the middle value is on the limit's open side.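

Compound 4 gives only a limit in this assay, > 100000 nM. Compound 3 also stands at a limit, so no size can be read for the change to (4-nitrobenzyl)oxy between compound 3 and compound 4. All four compounds sit together: the limit of > 100000 nM in this assay, at which 4 of the 4 values shown sit. None of the compounds shown gives a number, which leaves open whether the nitro group or the longer bridge alters antiproliferative activity at all.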